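The source may hold more compounds than are shown below. What is called first, only, known or untested is meant among the compounds shown, and "the series" means these compounds.

For the measured compounds named here, compound 1 `COc1ccccc1-c1cc(C2CCNC2)ccc1Cl` is the one compound here with a numerical reading: in a functional assay on HEK293 cells for agonist activity at 5-hydroxytryptamine receptor 7 (Homo sapiens), read by a luciferase reporter and beta-arrestin recruitment, with a stated time of 22 h (on this read-out lower numbers stand for smaller maximal responses and higher numbers for larger maximal responses), compound 1 gives 54%. Going by the values given here, compound 2 `CCCCNCc1ccc(Cl)c(-c2ccccc2OC)c1` shares the same core but carries a butyl chain on the amine nitrogen in place of the ring of compound 1; in this assay compound 2 is reported only as "not active" (no number reported), so no single number shows where it stands, and no measured step connects it to compound 1 or to anything else. Compound 3 `CCCNCc1ccc(Cl)c(-c2ccccc2OC)c1` has not yet been tested. It differs from compound 2 by hydrogen in place of methyl on a saturated chain carbon, three bonds along the chain from an amine nitrogen, which is a small trimming of the chain rather than any new group. The nearest neighbour with a reading, compound 2, showed no response at all, and nothing here links chain length to the size of the response. The expected step in this assay from compound 2 to compound 3 is therefore none beyond the usual scatter, or at most a modest rise from the floor. Compound 3 is estimated to reach 12%, within a range from 0% to 40%.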

Compound 3, largest response reached (Emax), in percent of the reference or control that the assay uses: "not active" (no number reported)
No number was reported for compound 3, so the estimate cannot be set against anything.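

In this assay, for the compounds shown here, compound 2 and compound 3 are both reported without a number, so no step between them can be read. Nothing shown offers an explanation for this result. The compounds shown leave open whether the length of the chain on the amine nitrogen has any bearing on the response.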